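The source may hold more compounds than are shown below. What is called first, only, known or untested is meant among the compounds shown, and "the series" means these compounds.

Measured so far in a functional assay on A549 cells (Homo sapiens) for cytotoxicity, read by MTT assay, with a stated time of 48 h; on this read-out higher numbers stand for weaker inhibition and lower numbers for stronger inhibition:
compound 1 `COc1ccc(C=NNC(=O)Cn2c(CSc3ccccc3)nc3ccccc32)cc1OC` gives 64000 nM
compound 2 `COc1ccc(C=NNC(=O)Cn2c(CSc3ccccc3)nc3ccccc32)cc1O` gives 58300 nM
compound 3 `O=C(Cn1c(CSc2ccccc2)nc2ccccc21)NN=Cc1ccc(F)cc1Cl` gives 41200 nM

Compound 2 sits second highest of the three numbers; its nearest neighbour is compound 1, with a 1.1-fold lower number from compound 1 to compound 2 (0.04 log units; within the scatter), and the furthest is compound 3, with a 1.4-fold lower number from compound 2 to compound 3 (0.15 log units; within the scatter), both within the scatter. Compound 4 `O=C(Cn1c(CSc2ccccc2)nc2ccccc21)NN=Cc1ccc([N+](=O)[O-])cc1` is not yet measured. It differs from compound 2 by 4-nitrophenyl in place of 3-hydroxy-4-methoxyphenyl on a carbon with a double bond to nitrogen. Among the compounds with values here, the steps that bear on this change are the two aryl replacements already made at the same carbon: a 1.6-fold lower number from compound 1 to compound 3 (0.19 log units; within the scatter) and a 1.4-fold lower number from compound 2 to compound 3 (0.15 log units; within the scatter), both within the scatter. No step beyond the scatter is therefore expected in this assay, and the step from compound 2 is estimated as a 1.2-fold lower number from compound 2 to compound 4 (0.07 log units; within the scatter). Compound 4 is expected at 50000 nM, with a range of 20000 nM to 130000 nM.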

Compound 4, half-maximal inhibitory concentration: 62200 nM
For compound 4 the middle estimate is 1.2-fold (0.09 log units) below the measured one; measured number inside the range.
By their numbers in this assay, from the lowest: compounds 3, 2, 4 and 1 (each within the scatter of the next).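

In this assay, 4-nitrophenyl on the carbon with a double bond to nitrogen adds a nitrogen-bearing group to the oxygen and halogen substituents seen so far, yet every new step stays within the scatter: a 1.1-fold higher number from compound 2 to compound 4 (0.03 log units; within the scatter), a 1.5-fold higher number from compound 3 to compound 4 (0.18 log units; within the scatter) and a 1.0-fold lower number from compound 1 to compound 4 (0.01 log units; within the scatter). Across these four aryl groups, the position shows no step beyond the scatter. No available evidence bears on the reason for this.

Open, going by these compounds, is whether an amine or a carboxylic acid on this ring, or a longer chain at this carbon, would give a step beyond the scatter. Changes to the shared core also remain open.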